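A few compounds are considered here, and "the series" means these few. Any claim that something is new, unique, unknown or untested is made for them only; others in the source may bear on it.

In a physicochemical assay for solubility, at pH 7 (a higher number here means a more soluble compound, a lower number a less soluble compound), three compounds built on a shared core have been measured. Compound 1 `CC1(C)c2[nH]nc(NC(=O)c3ccc(F)cc3)c2CN1C(=O)C1CCN(C2CC2)CC1` reaches the limit of the assay, reported as > 225000 nM. Compound 2 `CN1CCC(C(=O)N2Cc3c(NC(=O)Nc4cccc(F)c4)n[nH]c3C2(C)C)CC1` likewise returns only a limit, > 225000 nM. Compound 3 `CN1CCC(C(=O)Nc2n[nH]c3c2CN(C(=O)C(C)(C)C)C3(C)C)CC1` also sits at a limit, > 225000 nM. Among the compounds with values here, none of these is a true number; each marks the edge of what this assay can report, and that edge is the limit of > 225000 nM in this assay, at which 3 of the 3 values shown sit, so the measured set gives no ranking among them and no measured step between two numbers.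

Compound 4 `CCCNC(=O)Nc1n[nH]c2c1CN(C(=O)C1CCN(C)CC1)C2(C)C` is the compound still to be measured. It differs from compound 2 in one place, (propyl in place of 3-fluorophenyl on an amide-type nitrogen). Within the data shown here, no step between measured compounds covers this change, so what the limit on compound 2 shows is all there is to lean on. For compound 4 the expectation is that this assay again returns a limit rather than a number, with the estimated step that the limit leaves unreadable from compound 2 to compound 4 lying within the scatter. The estimate for compound 4 is 300000 nM, ranging from 150000 nM to 700000 nM.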

Compound 4, solubility: > 225000 nM
Compound 4: a limit, no number (the forecaster's own chance of this, stated with the estimate: 85%); the middle value lies beyond the limit too.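

No step can be read from compound 2 to compound 4, propyl in place of 3-fluorophenyl on an amide-type nitrogen, because both values are limits and not numbers: the limit of > 225000 nM in this assay, at which 4 of the 4 values shown sit.

The compounds shown leave open how these four would rank in this assay and how far apart they truly lie.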